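Replacing the iodo group of compound 2 with hydrogen

The source may hold more compounds than are shown below. What is called first, only, known or untested is meant among the compounds shown, and "the series" means these compounds.

Compound 1 `Oc1ccc2ccccc2c1C(Nc1nc2ccccc2s1)c1cn(-c2ccccc2)nc1-c1ccccc1` gives 17300 nM here
Compound 2 `COc1ccc2nc(NC(c3cn(-c4ccccc4)nc3-c3cccc(I)c3)c3c(O)ccc4ccccc34)sc2c1` gives 6240 nM here

In a functional assay on HeLa cells (Homo sapiens) for antiproliferative activity, read by MTT assay, with a stated time of 48 h (a higher number here means a weaker inhibitor, a lower number a stronger inhibitor), compound 2 at 6240 nM has the lower of the two measured numbers, and compound 1 at 17300 nM lies higher, beyond the usual scatter. Compound 3 `COc1ccc2nc(NC(c3cn(-c4ccccc4)nc3-c3ccccc3)c3c(O)ccc4ccccc34)sc2c1` is still unmeasured. It has hydrogen in place of iodo on an aromatic carbon of a six-membered aromatic ring of carbon only, meta to a large group, so 3-iodophenyl becomes phenyl hydrogen in place of iodo on an aromatic carbon with nothing else altered. Among the measured compounds shown here, no measured pair shows this change alone. Compound 1 also carries phenyl there and stands at 17300 nM, so the expectation leans upward. Expected in this assay is a small rise in the number, not beyond the scatter, with a 1.5-fold higher number from compound 2 to compound 3 (0.18 log units; within the scatter) as the estimated step. For compound 3 the expected value is 9500 nM, with an estimated range from 3500 nM to 22000 nM.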

Compound 3, half-maximal inhibitory concentration: 8290 nM
For compound 3 the middle estimate is 1.1-fold (0.06 log units) above the measured one; the measured number falls inside the stated range.
By their numbers in this assay, from the lowest: compounds 2 and 3 (each within the scatter of the next); then compound 1.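

In this assay, taking the iodo group off the 3-iodophenyl ring gives a 1.3-fold higher number from compound 2 to compound 3 (0.12 log units; within the scatter), so at this aromatic carbon, meta to a large group, the change from iodo to hydrogen does not separate the two compounds. The other single change, methoxy in place of hydrogen on an aromatic carbon, gives a 2.1-fold lower number from compound 1 to compound 3 (0.32 log units; beyond the scatter), a modest step, so the earlier gap between compound 1 and compound 2 goes with the methoxy group and not with the iodo group. Nothing available explains either step. The compounds shown leave open whether an amine or a carboxylic acid on that same aromatic carbon would shift the number beyond the scatter. They also leave open whether a longer alkoxy chain in place of the methoxy group would keep its step.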